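Swapping the carbonyl-bearing group for a methyloxazole

The compounds below may be only part of what the source reports. "The series", "measured", "known", "first", "only" and "open" are said of these compounds alone.

Compounds measured so far:
compound 1, `CC1=C(C(=O)CC(C)C)C(c2ccoc2)NC(=O)N1`: 18%
compound 2, `CCNC(=O)C1=C(C)NC(=O)NC1c1ccoc1`: 1%
compound 3, `CC1=C(C(=O)SC(C)C)C(c2ccoc2)NC(=O)N1`: 3%

In an assay on membranes from HeLa cells for displacement of a labelled ligand from adenosine receptor A3 (Homo sapiens), read by scintillation counting, with a stated time of 180 min, tested at 1 uM (a higher number here means more inhibition at the concentration tested (going by the name of the read-out), a lower number less inhibition), compound 3 gives 3%, the second highest of the three numbers. Its nearest neighbour is compound 2, whose value of 1% lies within the scatter of it; compound 1, with 18%, stands furthest away, the difference being beyond the scatter.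

Compound 4, `CC1=C(c2ncc(C)o2)C(c2ccoc2)NC(=O)N1`, differs from compound 3 in one place: 5-methyl-1,3-oxazol-2-yl in place of (isopropylsulfanyl)carbonyl on a double-bonded ring carbon. Going by the values given here, none of the measured steps removes the carbonyl itself. The steps that come closest all exchange the group on the carbonyl carbon: a number 17 percentage points lower from compound 1 to compound 2 (beyond the scatter), a number 15 percentage points lower from compound 1 to compound 3 (beyond the scatter) and a number 2 percentage points higher from compound 2 to compound 3 (within the scatter). They show that a change in this region of the shared core leaves no number higher than that of compound 1, and two of the three measured numbers sit near the bottom of the scale. For compound 4 the step from compound 3 is therefore expected to be small, a number 3 percentage points higher from compound 3 to compound 4 (within the scatter), with no firm direction. The estimated value for compound 4 is 6%, in a range from -5% to 20%.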

Compound 4, a percentage reported as inhibition, at one concentration (the size of the read-out at that concentration, not a potency): 1%
Compound 4: middle estimate off by 5 percentage points, on the high side, and the stated range covers the measured number.
By their numbers in this assay, from the lowest: compounds 2, 4 and 3 (each within the scatter of the next); then compound 1.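

Until now only the group on the carbonyl carbon had been exchanged, whereas compound 4 replaces the whole carbonyl-bearing group with a five-membered aromatic ring on the double-bonded ring carbon. In this assay this gives a number 2 percentage points lower from compound 3 to compound 4 (within the scatter) and no change at the digits printed from compound 2 to compound 4 (within the scatter) and so adds a third compound to the same low cluster, whether the group it replaces is (isopropylsulfanyl)carbonyl or ethylcarbamoyl. With a number 17 percentage points lower from compound 1 to compound 4 (beyond the scatter) as well, compound 1 and its isobutylcarbonyl group remain the only case set apart from the others, and nothing available here accounts for these numbers.

Going by these compounds, it remains open whether a longer chain on the carbonyl carbon, or a carboxylic acid on the ring carbon, would give a number above that of compound 1. Oxazoles with other substituents, or an oxazole carrying no methyl group, are equally untested by these compounds.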